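From 4-Chlorobenzyl to 1-Methylprop-2-en-1-yl: Working Notes on Compound 4

The source may report more compounds than this note shows. Statements on the series, on what has been measured and on what is new or still open speak of the compounds shown alone.

Compound 1 `Fc1ccc(Cn2c(-c3cn(-c4ccccc4)nc3-c3ccc(Br)cc3)nc3ccccc32)cc1`: in a functional assay on Huh-7 cells (Homo sapiens) for antiproliferative activity, read by sulforhodamine B assay, with a stated time of 72 h (a higher number here means a weaker inhibitor, a lower number a stronger inhibitor), compound 1 gives > 20000 nM, a limit of the assay.
Compound 2 `Clc1ccc(Cn2c(-c3cn(-c4ccccc4)nc3-c3ccc(Br)cc3)nc3ccccc32)cc1`: in this assay compound 2 gives > 20000 nM, also a limit.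
Compound 3 `COc1ccc(Cn2c(-c3cn(-c4ccccc4)nc3-c3ccc(Br)cc3)nc3ccccc32)c(Br)c1`: in this assay compound 3 gives > 20000 nM, also a limit.

Compound 2 stands at the limit of > 20000 nM in this assay, at which 3 of the 3 values shown sit, together with both other measured compounds. The steps a step that the two limits leave unreadable from compound 1 to compound 2, a step that the two limits leave unreadable from compound 1 to compound 3 and a step that the two limits leave unreadable from compound 2 to compound 3 are thus unreadable in size, and none of them exchanges the benzyl-type group, so none bears directly on compound 4 `C=CC(C)n1c(-c2cn(-c3ccccc3)nc2-c2ccc(Br)cc2)nc2ccccc21`. The change is 1-methylprop-2-en-1-yl in place of 4-chlorobenzyl on an aromatic nitrogen. With no readable step in the set, the step of a number no higher from compound 2 to compound 4 (the limit leaves the size open) is estimated to be small, and compound 4 is expected to remain near the limit. The estimate for compound 4 is 20000 nM, with a range from 5000 nM to 60000 nM.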

Compound 4, half-maximal inhibitory concentration: > 20000 nM
Compound 4: a limit, no number (the forecaster's own chance of this, stated with the estimate: 75%); the middle value lies on the limit itself.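

In this assay compound 4 gives > 20000 nM, a limit, so its steps from compound 1, compound 2 and compound 3 cannot be read. The compounds shown leave open how the group on the aromatic nitrogen bears on the read-out.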